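A few compounds are considered here, and "the series" means these few. Any claim that something is new, unique, unknown or untested is made for them only; others in the source may bear on it.

The study includes two measured compounds. Compound 1 `N#C/C(=C\N1CCN(C(=O)c2ccco2)C1=S)C(=O)c1ccccc1` in a functional assay on Malme-3M cells (Homo sapiens) for inhibition, read by sulforhodamine B assay, with a stated time of 48 h (on this read-out higher numbers stand for weaker inhibition of growth and lower numbers for stronger inhibition of growth), gives 30700 nM. Compound 2 `O=CN1CCN(c2ccc(Cl)cc2)C1=S` in this assay gives 24500 nM. Of these two numbers, compound 2 has the lower one, and its nearest neighbour is compound 1, whose number is higher only by an amount that falls within the usual scatter of repeated measurements, so the two compounds cannot be set apart on this read-out. Among the measured compounds shown here, no step between measured compounds that differ in a single place is available from these data.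

The step of interest leads from compound 2 to compound 3 `O=CN1CCN(c2ccc(Cl)c(Cl)c2)C1=S`, which has not yet been measured in this assay. The change is chloro in place of hydrogen on an aromatic carbon. For the measured compounds named here, nothing among the measured compounds shows what a change of this kind does on this read-out, so no step beyond the scatter is expected in either direction. Compound 3 is therefore expected to give about 20000 nM in this assay, within a range from 8000 nM to 50000 nM. The step that this estimate means, a 1.2-fold lower number from compound 2 to compound 3 (0.09 log units; within the scatter), is expected to lie within the scatter.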

Compound 3, concentration for 50% growth inhibition: 20400 nM
The estimate for compound 3 lay 1.0-fold (0.01 log units) below the measured number; the range from low to high includes it.
By their numbers in this assay, from the lowest: compounds 3, 2 and 1 (each within the scatter of the next).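

Among the compounds shown here, compound 2 and compound 3 form the only pair here that differs in one place, and so they give the first reading of this change. In this assay, chloro in place of hydrogen, on an aromatic carbon of a six-membered aromatic ring of carbon only, ortho to a chloro group and meta to a group of 8 heavy atoms, gives a 1.2-fold lower number from compound 2 to compound 3 (0.08 log units; within the scatter) and so does not shift the growth-inhibition read-out beyond the usual scatter, which means that this position accepts a second chloro with no change that can be told apart from repeat-to-repeat variation. No measured property is available that could account for this outcome.

For the compounds shown here, the single step covers only chloro at this one place, so it remains open whether a different group there, such as an amine, a methoxy group or a carboxylic acid, would move the number beyond the scatter. Also open, going by these compounds, is whether a longer chain in place of the group of 8 heavy atoms, or the same chloro change on the core of compound 1, would give a step of any greater size.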